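A Phenyl Swap Tested Against an Assay Ceiling

A few compounds are considered here, and "the series" means these few. Any claim that something is new, unique, unknown or untested is made for them only; others in the source may bear on it.

Measured so far in a functional assay on MCF7 cells (Homo sapiens) for antiproliferative activity, read by MTT assay, with a stated time of 48 h; a higher number here means a weaker inhibitor, a lower number a stronger inhibitor:
- Compound 1 `Cc1cccc(-n2nncc2CN2C(=O)C3(C(C#N)=C(N)Oc4c3c3nc5ccccc5nc3c3ccccc43)c3ccccc32)c1` gives > 50000 nM, which is a limit of this assay rather than a number.
- Compound 2 `N#CC1=C(N)Oc2c(c3nc4ccccc4nc3c3ccccc23)C12C(=O)N(Cc1cnnn1-c1cccc(S(N)(=O)=O)c1)c1ccccc12` gives 42500 nM.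
- Compound 3 `N#CC1=C(N)Oc2c(N)cc3nc4ccccc4nc3c2C12C(=O)N(Cc1cnnn1-c1ccc(Cl)cc1)c1ccccc12` gives > 50000 nM, again a limit of this assay and not a number.

Compound 3 therefore stands at the ceiling of this assay, where two of the three values shown sit (the limit of > 50000 nM in this assay, at which 2 of the 3 values shown sit). Compound 4 `Cc1ccc(-n2nncc2CN2C(=O)C3(C(C#N)=C(N)Oc4c(N)cc5nc6ccccc6nc5c43)c3ccccc32)cc1Cl` differs from it in one place: 3-chloro-4-methylphenyl in place of 4-chlorophenyl on an aromatic nitrogen.

One measured step speaks to a change on this phenyl ring. Going from compound 1 to compound 2, the change was an at least 1.1-fold lower number from compound 1 to compound 2 (0.07 log units; that floor lies within the scatter), and that step lies within the scatter. The step to compound 4 alters the same phenyl ring only by its halogen and methyl pattern, so no movement beyond the scatter is expected in this assay; the step from compound 3 to compound 4 is estimated as a number no higher from compound 3 to compound 4 (the limit leaves the size open). Compound 4 is expected to give about 50000 nM, within 20000 nM to 120000 nM, most likely reported again as a limit.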

Compound 4, half-maximal inhibitory concentration: > 50000 nM
Compound 4 was reported as a limit (the forecaster's own chance of this, stated with the estimate: 70%); the middle value lies on the limit itself.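

Compound 3 and compound 4 both give a limit rather than a number in this assay, so no step between them can be read: the limit of > 50000 nM in this assay, at which 3 of the 4 values shown sit.

The compounds shown leave open whether 3-chloro-4-methylphenyl in place of 4-chlorophenyl changes antiproliferative activity at all, and in which direction.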